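Swapping the Amide Substituent in a Slowly Cleared Series

The source may hold more compounds than are shown below. What is called first, only, known or untested is meant among the compounds shown, and "the series" means these compounds.

Compound 1 (`O=C(N[C@H]1CCOC[C@@H]1O)c1cn(Cc2ccc(-n3cccn3)cc2)c2cccnc12`) was tested in an ADME assay on liver for metabolic stability, with Liver microsome (Homo sapiens) as the target, using microsomes; a higher number here means faster removal of the compound, a lower number slower removal. In this assay compound 1 gives < 8 mL/min/kg, which is a limit of the assay rather than a measured number. A second member of the same series, compound 2 (`Cc1ccc2c(n1)c(C(=O)N[C@H]1CCOC[C@@H]1O)cn2Cc1ccc(-c2ccn(C)n2)cc1`), was measured in the same way. In this assay compound 2 gives < 8 mL/min/kg, again a limit. Among the measured compounds shown here, compound 1 therefore stands at the floor of what the assay reports, and so does the only other value shown: the limit of < 8 mL/min/kg in this assay, at which 2 of the 2 values shown sit. Compound 3 (`CN(C)C(=O)CNC(=O)c1cn(Cc2ccc(-n3cccn3)cc2)c2cccnc12`) differs from compound 1 in a single place: (dimethylcarbamoyl)methyl in place of 3-hydroxyoxan-4-yl on an amide-type nitrogen. For the measured compounds named here, no measured pair shows what this change does in this assay, so the expectation rests on where compound 1 stands alone. With both known values sitting at the limit, a step of a number no lower from compound 1 to compound 3 (the limit leaves the size open) is expected, meaning nothing beyond the scatter, although a move to a measurable number cannot be excluded. Compound 3 is estimated at 8 mL/min/kg, within a range from 4 mL/min/kg to 20 mL/min/kg in this assay.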

Compound 3, clearance: 9.3 mL/min/kg
Beside the measured number, compound 3's estimate is 1.2-fold (0.07 log units) below it; low and high end bracket the measured number.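

At the amide-type nitrogen, the series now has a compound that gives a measured number rather than a limit: with (dimethylcarbamoyl)methyl in place of 3-hydroxyoxan-4-yl, this assay shows an at least 1.1-fold higher number from compound 1 to compound 3 (0.06 log units; that floor lies within the scatter). This group has no ring and no defined stereocentres, so the ring and both stereocentres of 3-hydroxyoxan-4-yl can be lost from this position while the number stays close to the limit, with no step beyond the scatter established. The true size of the step remains unknown because one end of it is a limit, which gives only a floor for the change: the limit of < 8 mL/min/kg in this assay, at which 2 of the 3 values shown sit.

The compounds shown do not reveal whether an open chain with a hydroxyl group, such as 2-hydroxyethyl, or a group carrying an amine or a carboxylic acid, would give a lower or a higher number on the same amide-type nitrogen. As far as these compounds go, it also remains open whether the same swap would have a similar outcome on the core of compound 2, whose own value is a limit.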